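The source may hold more compounds than are shown below. What is called first, only, known or untested is meant among the compounds shown, and "the series" means these compounds.

Notes on the series. In a functional assay on PC-3 cells (Homo sapiens) for cytotoxicity, read by XTT assay, with a stated time of 72 h (a higher number here means a weaker inhibitor, a lower number a stronger inhibitor), compound 1 `CCCN(C)C(=O)c1ccc(-c2cc(-c3cc(OC)ccc3OC)no2)s1` gives > 30000 nM, which is a limit of the assay rather than a number. Compound 2 `O=C1C=CC(=O)C(c2cc(-c3ccc(C(=O)N4CCC(C(F)(F)F)CC4)s3)on2)=C1` gives in this assay > 30000 nM, also a limit. Compound 3 `O=C1C=CC(=O)C(c2cc(-c3ccc(C(=O)N4CCCCC4)s3)on2)=C1` gives in this assay > 30000 nM, a limit as well. For the measured compounds named here, the only measured step, a step that the two limits leave unreadable from compound 2 to compound 3, lies between two limits and has no readable size. All three values sit at the same point: the limit of > 30000 nM in this assay, at which 3 of the 3 values shown sit.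

Compound 4 `COc1ccc(OC)c(-c2cc(-c3ccc(C(=O)NC4CC4)s3)on2)c1` has not been measured in this assay. It differs from compound 1 by cyclopropylamino in place of methyl(propyl)amino on a carbonyl carbon.

Going by the values given here, no measured step touches this change; the one step in hand, from compound 2 to compound 3, alters a different part of the molecule and is itself unreadable. What the data show is that compound 1 gives only a limit, so the step that the limit leaves unreadable from compound 1 to compound 4 is expected to be small or not readable, with no direction given. Compound 4 is therefore estimated at 40000 nM, expected between 10000 nM and 150000 nM, most likely again reported as a limit.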

Compound 4, half-maximal inhibitory concentration: 7800 nM
Compound 4: middle estimate off by 5.1-fold (0.71 log units), on the high side; the whole stated range lies above it.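

In this assay, the group on the carbonyl carbon affects the read-out: cyclopropylamino in place of methyl(propyl)amino gives an at least 3.8-fold lower number from compound 1 to compound 4 (0.58 log units; beyond the scatter). On these data alone, compound 1 gives > 30000 nM, which is a limit and not a number, so the true size of this step stays unknown and only its lower bound is read. Compound 4 is the only compound shown with a readable number, so this change is the first to give the series a measurable point: the limit of > 30000 nM in this assay, at which 3 of the 4 values shown sit.

One pair cannot separate the three-membered ring from the amide hydrogen, and a propylamino or methylamino group on the same carbonyl carbon would bear on that question. As far as these compounds go, it also remains open whether cyclopropylamino would bring a readable number to compound 2 or compound 3, whose cores differ from that of compound 4.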